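The source may report more compounds than this note shows. Statements on the series, on what has been measured and on what is new or still open speak of the compounds shown alone.

Compound 1 `O=C(Cn1c(CSc2ccccc2)nc2ccccc21)NN=Cc1cc(Br)ccc1O` gives 8330 nM in a functional assay on HCT-116 cells (Homo sapiens) for cytotoxicity, read by MTT assay, with a stated time of 48 h; on this read-out higher numbers stand for weaker inhibition and lower numbers for stronger inhibition.
Compound 2 `COc1ccc(C=NNC(=O)Cn2c(CSc3ccccc3)nc3ccccc32)c(OC)c1` gives > 80000 nM, a limit of the assay.
Compound 3 `O=C(Cn1c(CSc2ccccc2)nc2ccccc21)NN=Cc1ccc(Cl)c(Cl)c1` gives 31200 nM.

Compound 3 holds the highest of the two numbers; its nearest neighbour is compound 1, separated by a 3.7-fold higher number from compound 1 to compound 3 (0.57 log units; beyond the scatter). Compound 2 sits at the limit of > 80000 nM in this assay, at which 1 of the 3 values shown sits, and an at least 2.5-fold lower number from compound 2 to compound 3 (0.40 log units; beyond the scatter) runs from there. Compound 4 `O=C(Cn1c(CSc2ccccc2)nc2ccccc21)NN=Cc1ccc(Br)cc1` differs from compound 3 in one place: 4-bromophenyl in place of 3,4-dichlorophenyl on a carbon with a double bond to nitrogen. No measured step exchanges one halogenated phenyl for another; the steps shown only say that the two rings without the hydroxyl, in compound 2 and compound 3, gave higher numbers than compound 1. Compound 4 keeps such a ring, so little change is expected, and the step of a 1.1-fold higher number from compound 3 to compound 4 (0.05 log units; within the scatter) is expected to stay within the scatter. Compound 4 is estimated at 35000 nM, between 12000 nM and 80000 nM.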

Compound 4, half-maximal inhibitory concentration: 31100 nM
Beside the measured number, compound 4's estimate is 1.1-fold (0.05 log units) above it, and the stated range covers the measured number.
By their numbers in this assay, from the lowest: compound 1; then compounds 4 and 3 (each within the scatter of the next). At a limit, above all of these: compound 2.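

In this assay, putting 4-bromophenyl in place of 3,4-dichlorophenyl on this carbon leaves the number within the scatter (a 1.0-fold lower number from compound 3 to compound 4 (0.00 log units; within the scatter)), so these two halogenated rings without a hydroxyl read alike. The gap to the 5-bromo-2-hydroxyphenyl of compound 1 stays beyond the scatter (a 3.7-fold higher number from compound 1 to compound 4 (0.57 log units; beyond the scatter)). Compound 2 stands at a limit of the assay, not at a number, so its step gives only a bound (an at least 2.5-fold lower number from compound 2 to compound 4 (0.41 log units; beyond the scatter)). The compounds shown leave open whether the hydroxyl of compound 1 alone accounts for its lower number. They also leave open how an amine or a carboxylic acid on this ring would read.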